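Furan-2-yl to furan-3-yl on the amide carbonyl

The compounds below may be only part of what the source reports. "The series", "measured", "known", "first", "only" and "open" are said of these compounds alone.

In a functional assay on BSY-1 cells (Homo sapiens) for inhibition, read by colorimetric assay and sulforhodamine B assay, with a stated time of 48 h (on this read-out higher numbers stand for weaker inhibition of growth and lower numbers for stronger inhibition of growth), compound 1 (`CCCCCCCCCCCC[C@@H](O)[C@H]1CC[C@H]([C@H](O)CCCCCCCCCCNC(=O)c2cccs2)O1`) gives 18200 nM. Within the data shown here, compound 2 (`CCCCCCCCCCCC[C@@H](O)[C@H]1CC[C@H]([C@H](O)CCCCCCCCCCNC(=O)c2ccco2)O1`) gives 490 nM, the lower of the two numbers so far. Compound 3 (`CCCCCCCCCCCC[C@@H](O)[C@H]1CC[C@H]([C@H](O)CCCCCCCCCCNC(=O)c2ccoc2)O1`) has the same atoms as compound 2, joined differently: furan-3-yl in place of furan-2-yl on a carbonyl carbon. Among the measured compounds shown here, only one measured step bears on this change, a 37-fold lower number from compound 1 to compound 2 (1.57 log units; beyond the scatter). It shows that the number can respond strongly to the ring on this carbonyl carbon. For the measured compounds named here, that step exchanges one ring for another, however, and no measured compound carries furan-3-yl, so its guidance is indirect. Since compound 2 stands at 490 nM, the lowest number yet seen, a move upward is expected, but one smaller than the measured step. The expected change is a 2.7-fold higher number from compound 2 to compound 3 (0.42 log units; beyond the scatter). For compound 3 the estimated value is 1300 nM, with an expected range of 300 nM to 6000 nM.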

Compound 3, concentration for 50% growth inhibition: 2190 nM
Estimate against measurement, compound 3: 1.7-fold (0.23 log units) below; the range from low to high includes it.
By their numbers in this assay, from the lowest: compound 2; then compound 3; then compound 1.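

In this assay, moving the attachment point of the same furan ring gives a 4.5-fold higher number from compound 2 to compound 3 (0.65 log units; beyond the scatter), so the number at this carbonyl carbon depends on how the ring is joined as well as on which ring is present. Furan-3-yl still compares favourably with thiophen-2-yl, with an 8.3-fold lower number from compound 1 to compound 3 (0.92 log units; beyond the scatter), which places both furans below the thiophene compound and furan-2-yl lowest of the three. No measurement is available that would account for this order among the rings.

As far as these compounds go, whether thiophen-3-yl would show a similar dependence on the attachment point remains open. Also open, from the compounds shown here alone, is how a phenyl or pyridin-2-yl ring on this carbonyl carbon would compare with the two furans.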